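A Methyl Moved Around the Triazole-Bound Phenyl

The compounds below may be only part of what the source reports. "The series", "measured", "known", "first", "only" and "open" are said of these compounds alone.

Compound 3 `Cc1ccccc1-n1cc(-c2cccc(NS(=O)(=O)c3c[nH]c(=O)[nH]c3=O)c2)nn1` gives 6230 nM in a functional assay on OVCAR-3 cells (Homo sapiens) for antiproliferative activity, read by MTT assay, with a stated time of 24 h (a higher number here means a weaker inhibitor, a lower number a stronger inhibitor), the second highest of three numbers. It stands within the scatter of compound 1 `O=c1[nH]cc(S(=O)(=O)Nc2ccccc2-c2cn(-c3ccccc3)nn2)c(=O)[nH]1`, which gives 6650 nM, and well above compound 2 `O=c1[nH]cc(S(=O)(=O)Nc2ccccc2-c2cn(-c3ccc(Cl)cc3)nn2)c(=O)[nH]1`, which gives 1750 nM. Compound 4 `Cc1ccc(-n2cc(-c3cccc(NS(=O)(=O)c4c[nH]c(=O)[nH]c4=O)c3)nn2)cc1` differs from compound 3 in one place: 4-methylphenyl in place of 2-methylphenyl on an aromatic nitrogen. Going by the values given here, the only measured step on this ring is a 3.8-fold lower number from compound 1 to compound 2 (0.58 log units; beyond the scatter), a different kind of change, so no measured step bears directly on the one made here. Since the two structures hold the same atoms joined differently, a step that stays within the scatter is expected for compound 4, estimated as a 1.2-fold lower number from compound 3 to compound 4 (0.10 log units; within the scatter). Compound 4 is therefore expected to give 5000 nM, with a range from 2000 nM to 12000 nM.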

Compound 4, half-maximal inhibitory concentration: 3540 nM
Estimate against measurement, compound 4: 1.4-fold (0.15 log units) above, and the stated range covers the measured number.
By their numbers in this assay, from the lowest: compound 2; then compounds 4, 3 and 1 (each within the scatter of the next).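

In this assay the swap of 2-methylphenyl for 4-methylphenyl on the aromatic nitrogen gives a 1.8-fold lower number from compound 3 to compound 4 (0.25 log units; within the scatter) and this step stays within the scatter. Going by these compounds alone, this is the first view of a methyl moved around this ring, and at this resolution the two placements cannot be told apart. No measurement shown here bears on why the step is this size.

On these data alone, it remains open whether a methoxy group or an amine in place of the methyl of 4-methylphenyl would give a step beyond the scatter.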